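The source may report more compounds than this note shows. Statements on the series, on what has been measured and on what is new or still open speak of the compounds shown alone.

Measured so far in an ADME assay on HEp-2 cells (Homo sapiens) for cytotoxicity, read by trypan blue exclusion, with a stated time of 24 h; a lower number here means that less compound is tolerated, a higher number that more compound is tolerated:
compound 1 `CC(C)=N/N=C1\SCC(=O)N1Cc1cccc([N+](=O)[O-])c1`: 5 ug/mL
compound 2 `O=C1CS/C(=N\N=C2CCCC2)N1Cc1ccc(Cl)cc1`: 16 ug/mL
compound 3 `C/C(=N\N=C1/SCC(=O)N1Cc1ccccc1F)c1cccs1`: 15 ug/mL

Compound 2 gives the highest of the three numbers in this assay. Compound 3 lies a small gap beneath it that is within the scatter, so the two are not separated; compound 1 lies beneath it by a gap beyond the scatter. Among the measured compounds shown here, no two measured compounds differ in a single place, so no step size is known from this series.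

The next compound is compound 4 `O=C1CS/C(=N\N=C2CCCC2)N1Cc1ccccc1F`, which differs from compound 2 by 2-fluorophenyl in place of 4-chlorophenyl on a saturated chain carbon bound to an amide-type nitrogen in a ring. The step from compound 2 to compound 4 in this assay is expected to be none beyond the scatter, because compound 3 gives 15 ug/mL while carrying the same 2-fluorophenyl at the same place, close to compound 2. Compound 4 is therefore expected near 15 ug/mL, within 7 ug/mL to 30 ug/mL. That estimate means a step of a 1.1-fold lower number from compound 2 to compound 4 (0.03 log units; within the scatter), within the scatter.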

Compound 4, half-maximal cytotoxic concentration in the HEp-2 assay: 11 ug/mL
Estimate against measurement, compound 4: 1.4-fold (0.13 log units) above; low and high end bracket the measured number.
By their numbers in the HEp-2 assay, from the lowest: compound 1; then compounds 4, 3 and 2 (each within the scatter of the next).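

Among the compounds shown here, in the HEp-2 assay, 2-fluorophenyl in place of 4-chlorophenyl on a saturated chain carbon bound to an amide-type nitrogen in a ring gives a 1.5-fold lower number from compound 2 to compound 4 (0.16 log units; within the scatter), the first single-place step, so this change does not separate the two compounds. In a physicochemical assay, with a stated time of 10 min (a higher number here means a weaker inhibitor, a lower number a stronger inhibitor), compound 2 sits at a limit of the assay, > 5000000 nM. In the physicochemical assay compound 4 also sits at a limit, > 5000000 nM.

The step between these two compounds in the physicochemical assay cannot be read, because both values are limits: the limit of > 5000000 nM in the physicochemical assay, at which 2 of the 2 values shown sit. As far as these compounds go, whether an amine or a carboxylic acid in place of these aromatic groups would shift the number in the HEp-2 assay remains open.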